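Swapping Methyl for Chloro: An Expected Outcome

This account rests on a few compounds, and the source may have more. Where it says the series, first, only, none or still open, it means among the compounds named here.

Compound 1 `Cc1ccc(/C=C2\CCC/C(=C\c3ccccc3)C2=O)cc1` was tested in an assay on isolated protein for inhibition of Alpha glucosidase (Homo sapiens), with stated times of 5 min and 15 min, tested at 50 uM (a lower number here means less inhibition, a higher number more inhibition at the concentration tested (going by the name of the read-out)), and gave 34.1%. Compound 2 `COc1cccc(/C=C2\CCC/C(=C\c3ccccc3)C2=O)c1OC`, measured in the same assay, gave 31.8%, so the two recorded numbers lie within the usual scatter of each other and compound 1 is not set apart by its result. Compound 3 `O=C1/C(=C/c2ccccc2)CCC/C1=C\c1ccc(Cl)cc1` differs from compound 1 in one place: chloro in place of methyl on an aromatic carbon. Among the measured compounds shown here, with no step between measured compounds to draw on, the expected change a number 0.9 percentage points higher from compound 1 to compound 3 (within the scatter) is none beyond the scatter. Compound 3 is therefore estimated at 35%, within 20% to 50%.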

Compound 3, a percentage reported as inhibition, at one concentration (the size of the read-out at that concentration, not a potency): 27.6%
Beside the measured number, compound 3's estimate is 7.4 percentage points above it, and the stated range covers the measured number.
By their numbers in this assay, from the lowest: compounds 3, 2 and 1 (each within the scatter of the next).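

Among the compounds shown here, with a number 6.5 percentage points lower from compound 1 to compound 3 (within the scatter) in this assay the swap of methyl for chloro gives the one direct comparison at a single place, which compounds 1 and 2 could not offer. At this position, on an aromatic carbon para to a large group, the read-out does not tell the two groups apart. Nothing measured here bears on why this is so. Going by these compounds, whether an amine, a carboxylic acid or a longer chain at this position would stand apart from methyl stays open, as does whether the same swap elsewhere on the shared core gives a similar result.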